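Turning one double bond around in compound 2

The source may hold more compounds than are shown below. What is called first, only, known or untested is meant among the compounds shown, and "the series" means these compounds.

Two close relatives already have numbers. In a functional assay on cells (Endothelial cell, Bos taurus) for antiproliferative activity (on this read-out higher numbers stand for weaker inhibition and lower numbers for stronger inhibition), compound 1 `COc1ccc(/C=C(\F)c2cc(OC)c(OC)c(OC)c2)cc1O` gives 13000 nM, while compound 2 `COc1ccc(/C=C(/F)c2cc(OC)c(OC)c(OC)c2)cc1N` gives 2000 nM. Compound 2 therefore holds the lower of the two numbers, and its gap to compound 1 lies beyond the usual scatter.

Compound 3 `COc1ccc(/C=C(\F)c2cc(OC)c(OC)c(OC)c2)cc1N` keeps the same atoms and bonds as compound 2 and changes only its configuration as drawn: the two compounds have the same atoms and bonds and differ only in configuration as drawn: 1 of 1 stereo elements differ; a double bond is drawn E in compound 2 and Z in compound 3. For the measured compounds named here, no two measured compounds differ in one place alone, so no measured step shows what this switch does. In this assay, a move towards weaker inhibition beyond the scatter is expected, with compound 1 at 13000 nM showing how high a close relative can sit. The estimated step is a 3.5-fold higher number from compound 2 to compound 3 (0.54 log units; beyond the scatter). For compound 3 the expected value is 7000 nM, within an estimated range of 1800 nM to 28000 nM.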

Compound 3, half-maximal inhibitory concentration: 86000 nM
Compound 3: the middle estimate sits 12-fold (1.09 log units) below what was measured, outside the stated range (above it).
By their numbers in this assay, from the lowest: compound 2; then compound 1; then compound 3.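

Turning the double bond from E to Z is enough on its own to weaken inhibition sharply, with a 43-fold higher number from compound 2 to compound 3 (1.63 log units; beyond the scatter), and this large step can be assigned to that single change: the fact that compounds 2 and 3 differ only in the configuration as drawn

With the Z double bond kept, the ring group matters as well: amino in place of hydroxy on an aromatic carbon gives a 6.6-fold higher number from compound 1 to compound 3 (0.82 log units; beyond the scatter), so among these Z compounds the hydroxy compound 1 holds the lower number. The step labelled modest is the smaller of the two, and the amino group gives no advantage when the double bond is Z, even though compound 2 holds the lowest number of the set.

Going by these compounds, it remains open whether a hydroxy group would respond as strongly to the same turn of the double bond. How a methylamino group in that place would behave with either double bond geometry is also unknown.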